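The source may hold more compounds than are shown below. What is called first, only, known or untested is meant among the compounds shown, and "the series" means these compounds.

Three compounds share a core and were tested in an assay on HEK293 cells for binding affinity to 5-hydroxytryptamine receptor 7 (Homo sapiens), read by radioligand binding, tested at 1 uM; on this read-out lower numbers stand for less inhibition and higher numbers for more inhibition at the one concentration tested (going by the name of the read-out). Compound 1 `Brc1ccc2ccn(CCN3CCN(C4CCCCC4)CC3)c2c1` gives 36%, compound 2 `C#Cc1ccc2ccn(CCN3CCCN(C)CC3)c2c1` gives 79%, and compound 3 `Brc1ccc2ccn(CCN3CCCNCC3)c2c1` gives 77%. Compound 3 thus stands second highest of the three; its nearest neighbour is compound 2, whose number lies within the scatter, while compound 1 lies far below it, beyond the scatter. Compound 4 `Brc1ccc2ccn(CCN3CCCN(CC4CC4)CC3)c2c1` differs from compound 3 in one place: cyclopropylmethyl in place of hydrogen on an amine nitrogen in a ring. Among the measured compounds shown here, no measured pair shows this exact step, so its size is open; compound 2 shows that a small group on that nitrogen leaves the number near that of compound 3, whereas compound 1 carries a larger ring group and sits much lower. A moderate decrease is expected from compound 3 to compound 4, a number 12 percentage points lower from compound 3 to compound 4 (beyond the scatter), possibly no larger than the scatter. Compound 4 is therefore estimated at 65%, with a range from 40% to 85%.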

Compound 4, a percentage reported as inhibition, at one concentration (the size of the read-out at that concentration, not a potency): 95%
Beside the measured number, compound 4's estimate is 30 percentage points below it, outside the stated range (above it).
By their numbers in this assay, from the lowest: compound 1; then compounds 3 and 2 (each within the scatter of the next); then compound 4.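

In this assay, cyclopropylmethyl in place of hydrogen gives a number 18 percentage points higher from compound 3 to compound 4 (beyond the scatter) at this amine nitrogen in the seven-membered ring. Among the compounds shown here, this is the first step read at this position, and it shows that a substituent with a three-membered ring can raise the number there. Nothing available explains the size of this step.

Going by these compounds, whether the three-membered ring itself matters stays open, as an open butyl chain or cyclobutylmethyl on the same nitrogen would show. On these data alone, the effect of benzyl or a longer chain there also remains unknown.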